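The source may hold more compounds than are shown below. What is called first, only, known or untested is meant among the compounds shown, and "the series" means these compounds.

Measured so far:
compound 1, `CCOc1ccc(-n2nncc2CN2C(=O)C3(C(C#N)=C(N)Oc4c3c3nc5ccccc5nc3c3ccccc43)c3ccccc32)cc1`: > 50000 nM
compound 2, `N#CC1=C(N)Oc2c(c3nc4ccccc4nc3c3ccccc23)C12C(=O)N(Cc1cnnn1-c1ccc(N)cc1)c1ccccc12`: > 50000 nM

In an ADME assay on HUVEC cells (Homo sapiens) for antiproliferative activity, read by MTT assay, with a stated time of 48 h (a higher number here means a weaker inhibitor, a lower number a stronger inhibitor), compound 1 reaches only a limit of the assay, > 50000 nM. Compound 2 likewise reaches only a limit, > 50000 nM. Going by the values given here, the step that the two limits leave unreadable from compound 1 to compound 2 therefore gives no size, since (the limit of > 50000 nM in this assay, at which 2 of the 2 values shown sit); compound 2 stands at that limit, and the one further value shown is the same limit, so nothing places compound 2 above or below compound 1 in this assay.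

The next compound is compound 3, `N#CC1=C(N)Oc2c(c3nc4ccccc4nc3c3ccccc23)C12C(=O)N(Cc1cnnn1-c1cc(Cl)ccc1Cl)c1ccccc12`. The change from compound 2 is 2,5-dichlorophenyl in place of 4-aminophenyl on an aromatic nitrogen.

Among the compounds with values here, the only measured step that bears on this change is the one from compound 1 to compound 2, and it is unreadable. Within the data shown here, with both values at the limit, no measured step gives a size or a direction to carry over. The expectation is therefore that compound 3 also sits at or near the limit, with no step beyond the scatter. Compound 3 is estimated to give 60000 nM, in the range 20000 nM to 200000 nM. That estimate means an expected step that the limit leaves unreadable from compound 2 to compound 3, which is taken to be none beyond the scatter.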

Compound 3, half-maximal inhibitory concentration: > 50000 nM
Compound 3 was reported as a limit; the forecaster's own chance of this, stated with the estimate: 80%; the middle value lies beyond the limit too.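

In this assay compound 3 gives > 50000 nM as a limit of the assay and not as a number. Going by these compounds alone, no step among compound 1, compound 2 and compound 3 can be read: the limit of > 50000 nM in this assay, at which 3 of the 3 values shown sit. The compounds shown leave open whether any group on the aromatic nitrogen gives a value in this assay that is not at this limit.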